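Indole in place of benzimidazole on the shared core

A few compounds are considered here, and "the series" means these few. Any claim that something is new, unique, unknown or untested is made for them only; others in the source may bear on it.

Measured compounds:
compound 1 `COc1ccccc1N1CCN(CCCn2nc(-n3cnc4ccccc43)ccc2=O)CC1`: 6.5 nM
compound 2 `O=c1ccc(-n2cnc3ccccc32)nn1CCCN1CCN(c2ccccc2Cl)CC1`: 15.2 nM
compound 3 `O=c1ccc(-n2ccnc2)nn1CCCCN1CCN(c2ccccc2Cl)CC1`: 24.6 nM

In an assay on cell membranes from brain for binding affinity to Adrenergic receptor alpha-1 (Rattus norvegicus), read by radioligand binding (a lower number here means a stronger inhibitor, a higher number a weaker inhibitor), compound 1 gives the lowest of the three numbers; compound 2 comes nearest, by a 2.3-fold higher number from compound 1 to compound 2 (0.37 log units; beyond the scatter), and compound 3 lies further off still. Compound 4 `COc1ccccc1N1CCN(CCCn2nc(-n3ccc4ccccc43)ccc2=O)CC1` differs from compound 1 by 1H-indol-1-yl in place of 1H-benzimidazol-1-yl on an aromatic carbon. Among the compounds with values here, no measured step touches this group alone: the one single-place step, a 2.3-fold higher number from compound 1 to compound 2 (0.37 log units; beyond the scatter), concerns the substituent at the far end of the molecule, and compound 3 differs from compound 2 in both the heteroaryl group and the chain, so it isolates nothing. Within the data shown here, with no directly bearing step, a change within the scatter or a modest rise is expected, as a 1.7-fold higher number from compound 1 to compound 4 (0.23 log units; within the scatter). Compound 4 is estimated at 11 nM, between 4 nM and 32 nM.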

Compound 4, inhibition constant: 3.2 nM
The estimate for compound 4 lay 3.4-fold (0.54 log units) above the measured number; the measured number lies below the stated range.
By their numbers in this assay, from the lowest: compound 4; then compound 1; then compounds 2 and 3 (each within the scatter of the next).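

In this assay, the change of 1H-benzimidazol-1-yl to 1H-indol-1-yl on the aromatic carbon next to the ring nitrogen gives a 2.0-fold lower number from compound 1 to compound 4 (0.31 log units; beyond the scatter), the first single-place step read at this position. Within this pair, replacing a nitrogen of the five-membered aromatic ring with carbon, and so leaving one hydrogen-bond acceptor fewer, does not raise the number. Nothing at hand accounts for the step.

Open, going by these compounds, is whether 1H-indol-1-yl keeps this gain with chloro in place of methoxy or with a longer chain. Also open, on these data alone, is how a simple amine or 1H-pyrrol-1-yl would read on the same aromatic carbon.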